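A few compounds are considered here, and "the series" means these few. Any claim that something is new, unique, unknown or untested is made for them only; others in the source may bear on it.

In a functional assay on DLD-1 cells (Homo sapiens) for antiproliferative activity, read by sulforhodamine B assay, with a stated time of 48 h (on this read-out lower numbers stand for stronger inhibition and higher numbers for weaker inhibition), compound 1 `COc1ccc(-c2oc3c(OC)c(OC)cc(OCCCC(=O)N4CCN(C)CC4)c3c(=O)c2O)cc1` gives > 40000 nM, which is a limit and not a number. Compound 2 `COc1ccc(-c2oc3c(OC)c(OC)cc(OCCCCC(=O)NCc4ccccn4)c3c(=O)c2O)cc1` gives > 40000 nM, also a limit. Compound 3 `COc1ccc(-c2oc3c(OC)c(OC)cc(OCCCCC(=O)N4CCN(C)CC4)c3c(=O)c2O)cc1` gives > 40000 nM, again a limit. All three therefore stand at the limit of > 40000 nM in this assay, at which 3 of the 3 values shown sit. Compound 4 `COc1ccc(-c2oc3c(OC)c(OC)cc(OC(C)CN(C)C)c3c(=O)c2O)cc1` keeps the core of compound 1 and alters the group on an oxygen on an aromatic ring: 1-((dimethylamino)methyl)ethyl in place of 3-((4-methylpiperazin-1-yl)carbonyl)propyl on an oxygen on an aromatic ring. The measured steps that bear on this change are a step that the two limits leave unreadable from compound 1 to compound 2, a step that the two limits leave unreadable from compound 1 to compound 3 and a step that the two limits leave unreadable from compound 2 to compound 3. None has a readable size, so they indicate no direction, and only a small move towards stronger inhibition is expected. The expected change is an at least 1.3-fold lower number from compound 1 to compound 4 (0.12 log units; that floor lies within the scatter). The estimate for compound 4 is 30000 nM, with an expected range from 8000 nM to 60000 nM.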

Compound 4, half-maximal inhibitory concentration: 2560 nM
The estimate for compound 4 lay 12-fold (1.07 log units) above the measured number, outside the stated range (below it).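

In this assay, 1-((dimethylamino)methyl)ethyl in place of 3-((4-methylpiperazin-1-yl)carbonyl)propyl on an oxygen on an aromatic ring gives an at least 15-fold lower number from compound 1 to compound 4 (1.19 log units; beyond the scatter). The steps among compound 1, compound 2 and compound 3 cannot be read, so this is the first step of readable size, and compound 4 alone carries a number rather than a limit: the limit of > 40000 nM in this assay, at which 3 of the 4 values shown sit.

The change removes the ring and the carbonyl together, and the compounds shown do not separate these two parts. They also leave open whether an unbranched dimethylaminopropyl chain or a morpholine-bearing chain on this oxygen would give a similar number.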